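The source may report more compounds than this note shows. Statements on the series, on what has been measured and on what is new or still open speak of the compounds shown alone.

Working notes on the series. Among the measured compounds shown here, in an assay on a cell-free system (plasma) for antagonist activity at proteinase-activated receptor 4 (Homo sapiens), with a stated time of 5 min, in the presence of a further agent that is not named here (on this read-out lower numbers stand for stronger inhibition and higher numbers for weaker inhibition), compound 3 `COc1cc(OCc2cccc(CCc3ccccc3)c2)c2cc(-c3cn4nc(OC)sc4n3)oc2c1` gives 1200 nM, the lowest of the two numbers so far. Compound 2 `COc1cc(OCc2cccc(O)c2)c2cc(-c3cn4nc(OC)sc4n3)oc2c1` gives 2700 nM in this assay. Compound 1 `COc1nn2cc(-c3cc4ccc(OCc5ccccc5)cc4o3)nc2s1` returns only a limit in this assay, namely > 30000 nM; this is the limit of > 30000 nM in this assay, at which 1 of the 3 values shown sits, and is not a number. For the measured compounds named here, the single measured step is a 2.3-fold lower number from compound 2 to compound 3 (0.35 log units; beyond the scatter), a modest gain that stands beyond the scatter.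

Compound 4 `COc1cc(OCc2cccc(C#N)c2)c2cc(-c3cn4nc(OC)sc4n3)oc2c1` differs from compound 3 by cyano in place of phenethyl on an aromatic carbon. The change takes away the very group whose entry produced a 2.3-fold lower number from compound 2 to compound 3 (0.35 log units; beyond the scatter) and puts a cyano at the same aromatic carbon. Going by the values given here, no measured step covers a cyano here, so that one step is the only guide, and it bears on the present change only in reverse: the phenethyl that helped is gone, and what replaces it has no precedent in the set. The working assumption is that the number in this assay moves back toward that of compound 2 rather than improving further.

For compound 4 a step of about a 2.1-fold higher number from compound 3 to compound 4 (0.32 log units; beyond the scatter) is expected. The estimate for compound 4 in this assay is 2500 nM, with a range from 900 nM to 7000 nM.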

Compound 4, half-maximal inhibitory concentration: 820 nM
For compound 4 the middle estimate is 3.0-fold (0.48 log units) above the measured one, and the stated range ends above it.
By their numbers in this assay, from the lowest: compounds 4 and 3 (each within the scatter of the next); then compound 2. At a limit, above all of these: compound 1.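

In this assay, cyano in place of phenethyl on this aromatic carbon gives a 1.5-fold lower number from compound 3 to compound 4 (0.17 log units; within the scatter), so the small group and the large one cannot be told apart here, and the six-membered aromatic ring of the phenethyl is not required to hold the number at this level. Measured against hydroxy on the same carbon, the cyano gives a 3.3-fold lower number from compound 2 to compound 4 (0.52 log units; beyond the scatter), and the phenethyl gives a 2.3-fold lower number from compound 2 to compound 3 (0.35 log units; beyond the scatter), so two entering groups that differ widely in size both part from hydroxy by more than the scatter. Nothing measured for these compounds accounts for either the match between cyano and phenethyl or their separation from hydroxy.

Still open, going by these compounds, is whether the separation follows from the loss of hydroxy or from what enters in its place, a question that an amine, a carboxylic acid, a methyl or a plain hydrogen on this carbon would help to settle. Also open, on these data alone, is whether a benzyl or a chain longer than phenethyl reads alongside these compounds, and whether cyano gives the same result on another carbon of this ring.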